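This account rests on a few compounds, and the source may have more. Where it says the series, first, only, none or still open, it means among the compounds named here.

Measured in a functional assay on MDA-MB-231 cells (Homo sapiens) for cytotoxicity, read by MTT assay, with a stated time of 48 h; a higher number here means a weaker inhibitor, a lower number a stronger inhibitor:
- Compound 1 `COc1ccccc1Nc1nc(-c2cccc(F)c2)nc2ccc(F)cc12`: > 50000 nM, a limit
- Compound 2 `Fc1cccc(-c2nc(Nc3ccc(Br)cc3)c3cc(F)ccc3n2)c1`: > 50000 nM, a limit
- Compound 3 `Fc1cccc(-c2nc(Nc3cccc(Br)c3)c3cc(F)ccc3n2)c1`: > 50000 nM, a limit

Compound 3 has no number in this assay, only a limit, and the series as a whole rests on (the limit of > 50000 nM in this assay, at which 3 of the 3 values shown sit). Compound 4 `Oc1ccc(Nc2nc(-c3cccc(F)c3)nc3ccc(F)cc23)cc1` carries 4-hydroxyphenyl in place of 3-bromophenyl on a nitrogen on an aromatic ring. Three measured changes at this same place bear on it: a step that the two limits leave unreadable from compound 1 to compound 2, a step that the two limits leave unreadable from compound 1 to compound 3 and a step that the two limits leave unreadable from compound 2 to compound 3. None of them offers a size or a direction to carry over. Resting on the limit of compound 3, > 50000 nM, no step beyond the scatter is expected in this assay. The estimated change is an at least 1.1-fold lower number from compound 3 to compound 4 (0.04 log units; that floor lies within the scatter). For compound 4 the expected value is 45000 nM, with an estimated range of 12000 nM to 100000 nM.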

Compound 4, half-maximal inhibitory concentration: > 50000 nM
Compound 4 ended at the assay's limit; the forecaster's own chance of this, stated with the estimate: 60%; middle value at least 1.1-fold (0.04 log units) away from the limit.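

In this assay compound 4 gives > 50000 nM as a limit, so its steps from compound 1, compound 2 and compound 3 cannot be read. Whether any group at this place gives a readable number stays open, as the series rests on a single limit: the limit of > 50000 nM in this assay, at which 4 of the 4 values shown sit.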